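A few compounds are considered here, and "the series" means these few. Any claim that something is new, unique, unknown or untested is made for them only; others in the source may bear on it.

Measured in a functional assay on A549 cells (Homo sapiens) for antiproliferative activity, read by MTT assay, with a stated time of 48 h; on this read-out lower numbers stand for stronger inhibition and higher numbers for weaker inhibition:
- compound 1 `COc1ccc2[nH]c(-c3cn(-c4ccccc4)nc3-c3ccccc3)nc2c1`: 1230 nM
- compound 2 `COc1ccc(-c2nn(-c3ccccc3)cc2-c2nc3cc(F)ccc3[nH]2)cc1`: 1980 nM
- compound 3 `COc1ccc(-c2nn(-c3ccccc3)cc2-c2nc3cc(Br)ccc3[nH]2)cc1`: 6370 nM

Of these three, compound 3 gives the highest number, 6370 nM. Compound 4 `COc1ccc(-c2nn(-c3ccccc3)cc2-c2nc3cc(OC)ccc3[nH]2)cc1` has methoxy in place of bromo on an aromatic carbon. Among the compounds with values here, no measured step makes this exchange directly. The nearest evidence is a 3.2-fold higher number from compound 2 to compound 3 (0.51 log units; beyond the scatter), a modest step in which bromo replaces fluoro on an aromatic carbon. Compound 1, which also carries a methoxy on the shared core, stands lower at 1230 nM. A modest step to a lower number in this assay is therefore expected, of about the same size as that one. The expected step is a 2.5-fold lower number from compound 3 to compound 4 (0.41 log units; beyond the scatter). For compound 4 the estimated value is 2500 nM, with an expected range of 900 nM to 6500 nM.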

Compound 4, half-maximal inhibitory concentration: 22700 nM
Estimate against measurement, compound 4: 9.1-fold (0.96 log units) below, and the stated range ends below it.
By their numbers in this assay, from the lowest: compounds 1 and 2 (each within the scatter of the next); then compound 3; then compound 4.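

In this assay, within the data shown here, methoxy on this aromatic carbon gives a higher number than either halogen, with a 3.6-fold higher number from compound 3 to compound 4 (0.55 log units; beyond the scatter) and an 11-fold higher number from compound 2 to compound 4 (1.06 log units; beyond the scatter), so the order here runs fluoro, bromo, methoxy, and the oxygen-bearing group, not a halogen, gives the highest number so far. The exchange of methoxy for hydrogen, an 18-fold higher number from compound 1 to compound 4 (1.27 log units; beyond the scatter), is also large. Nothing measured here explains these steps. On these data alone, it remains open how an amine or a carboxylic acid on this carbon would compare with fluoro, bromo and methoxy.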